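The compounds below may be only part of what the source reports. "The series", "measured", "known", "first", "only" and "open" are said of these compounds alone.

The measured compounds, in brief:

Compound 1 `O=C1/C(=C/c2ccccc2Cl)Cc2ccccc21`, which in a functional assay on Molt4/C8 cells (Homo sapiens) for inhibition (a lower number here means a stronger inhibitor, a higher number a weaker inhibitor), gives 128000 nM.
Compound 2 `O=C1/C(=C/c2ccc(Cl)cc2Cl)Cc2ccccc21`, which in this assay gives only a limit, > 500000 nM.
Compound 3 `COc1ccc(/C=C2\CCCc3ccccc3C2=O)cc1OC`, which in this assay gives only a limit, > 20000 nM.

Going by the values given here, compound 1 is therefore the single compound of the three with an actual number in this assay; the other two sit at limits, one at the limit of > 20000 nM in this assay, at which 1 of the 3 values shown sits, and one at the limit of > 500000 nM in this assay, at which 1 of the 3 values shown sits. The unmeasured compound 4 `O=C1/C(=C/c2ccccc2Br)Cc2ccccc21` differs from compound 1 in one place: bromo in place of chloro on an aromatic carbon.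

Among the compounds with values here, only one measured step exists, an at least 3.9-fold higher number from compound 1 to compound 2 (0.59 log units; beyond the scatter), and it concerns a second chloro entering on an aromatic carbon rather than the exchange of one halogen for another. It bears on the present question only loosely. An exchange of chloro for bromo at the same place is a small change, and compound 4 is expected to stay close to compound 1, with a step of a 1.2-fold lower number from compound 1 to compound 4 (0.07 log units; within the scatter) that is expected to lie within the scatter of this assay. The estimate for compound 4 is 110000 nM, with a range from 40000 nM to 300000 nM.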

Compound 4, half-maximal inhibitory concentration: 95400 nM
Compound 4: middle estimate off by 1.2-fold (0.06 log units), on the high side; the measured number falls inside the stated range.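

At this place, on an aromatic carbon of a six-membered aromatic ring of carbon only, ortho to a large group, this assay does not tell the two halogens apart, as the step shows: a 1.3-fold lower number from compound 1 to compound 4 (0.13 log units; within the scatter). Going by these compounds alone, the earlier step concerned a second chloro entering the ring, whereas this pair keeps the number of halogens on the ring fixed and exchanges only the halogen itself, and it is the first pair in which both compounds carry an actual number rather than a limit. It thus shows that, on the core of compound 1, a single halogen at this place can be chloro or bromo with no difference beyond the scatter, though nothing shown accounts for this result.

On these data alone, how an amine, a carboxylic acid or a nitrile at this place would read in this assay remains open, as does whether any group there could give a much lower number than the two halogens do. Also open, as far as these compounds go, is whether the same exchange would read alike on compound 2, whose > 500000 nM is a limit and not a number.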